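Compound 2 to compound 4: methyl in place of fluoro

The source may hold more compounds than are shown below. What is called first, only, known or untested is meant among the compounds shown, and "the series" means these compounds.

In a functional assay on KG-1 cells (Homo sapiens) for cytotoxicity, read by luminescence and CellTiter-Glo, with a stated time of 3 days (a higher number here means a weaker inhibitor, a lower number a stronger inhibitor), compound 1 (`N#Cc1ccc(NC(=O)c2ccc(Br)cc2O)cc1Cl`) gives 960 nM and compound 3 (`O=C(Nc1ccc(C(F)(F)F)cc1)c1cc(Cl)c(-c2ccccc2)cc1O`) gives 770 nM while compound 2 (`N#Cc1ccc(NC(=O)c2ccc3cccnc3c2O)c(F)c1`) gives 3260 nM as the highest number of the three. Compound 2 lies beyond the scatter from both others and is the weakest inhibitor of this small set.

Compound 4 (`Cc1cc(C#N)ccc1NC(=O)c1ccc2cccnc2c1O`) is the next case. Against compound 2 it has methyl in place of fluoro on an aromatic carbon, and the count of the change reads methyl in place of fluoro on an aromatic carbon in full. Within the data shown here, the measured compounds contain no pair that differs in one place, so they give no direct guide to the size of this step. No step beyond the scatter is therefore expected in this assay and no direction is favoured. The expected step is small: a 1.1-fold lower number from compound 2 to compound 4 (0.04 log units; within the scatter) as estimated here. With compound 2 at 3260 nM as the anchor, the estimate stays close to that number. Compound 4 is expected at 3000 nM (estimated range 1200 nM to 7500 nM).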

Compound 4, half-maximal inhibitory concentration: 3240 nM
Compound 4: middle estimate off by 1.1-fold (0.03 log units), on the low side; measured number inside the range.
By their numbers in this assay, from the lowest: compounds 3 and 1 (each within the scatter of the next); then compounds 4 and 2 (each within the scatter of the next).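

In this assay, methyl in place of fluoro on an aromatic carbon, ortho to a large group and meta to a cyano group, gives a 1.0-fold lower number from compound 2 to compound 4 (0.00 log units; within the scatter) and stays within the scatter. Among these compounds, this is the first reading of a change in one place, which the earlier compounds, differing from one another in several places, could not give. At this position, with the rest of compound 2 held fixed, fluoro and methyl cannot be told apart by this read-out, although that finding rests on this single pair.

Going by these compounds, whether an amine, a carboxylic acid or a longer chain at the same position would leave the number as flat remains open, as does whether methyl in place of fluoro would read the same on the cores of compound 1 and compound 3. No outside measurement bears on why this step is so small.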